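The source may hold more compounds than are shown below. What is called first, only, known or untested is meant among the compounds shown, and "the series" means these compounds.

Measured in an ADME assay on MT4 cells (Homo sapiens) for cytotoxicity, with a stated time of 5 days; a higher number here means that more compound is tolerated, a lower number that less compound is tolerated:
Compound 1 `CC(C)(C)C#Cc1cc(N(C(=O)[C@H]2CC[C@H](C)CC2)[C@H]2CC[C@H](Oc3ccc4nccn4n3)CC2)c(C(=O)O)s1`: 133 nM
Compound 2 `CC(C)(C)C#Cc1cc(N(C(=O)[C@H]2CC[C@H](C)CC2)[C@H]2CC[C@H](OC3COC3)CC2)c(C(=O)O)s1`: 8350 nM

Of these two compounds, compound 1 has the lower number, at 133 nM. Compound 3 `CC(C)(C)C#Cc1cc(N(C(=O)[C@H]2CC[C@H](C)CC2)[C@H]2CC[C@H](Oc3ccc(=O)[nH]n3)CC2)c(C(=O)O)s1` has not yet been measured in this assay. It differs from compound 1 by one change, (a group of 7 heavy atoms (4 carbon, 2 nitrogen, 1 oxygen; one six-membered aromatic ring with 2 hetero atoms) in place of a group of 9 heavy atoms (6 carbon, 3 nitrogen; one five-membered aromatic ring with 2 hetero atoms, one six-membered aromatic ring with 2 hetero atoms), on an oxygen on a saturated carbon), on an oxygen on a saturated carbon, where the one six-membered aromatic ring that enters replaces a pair of aromatic rings.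

Going by the values given here, one measured step bears on this: the same group leaves at the same place in a 63-fold higher number from compound 1 to compound 2 (1.80 log units; beyond the scatter), a large step. Compound 2 carries a different entering group, so this single step is only a partial guide. A similar upward step, somewhat smaller, is therefore expected: a 38-fold higher number from compound 1 to compound 3 (1.58 log units; beyond the scatter). The estimated value for compound 3 is 5000 nM, with an expected range from 1000 nM to 25000 nM.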

Compound 3, half-maximal cytotoxic concentration in the MT4 assay: 1480 nM
For compound 3 the middle estimate is 3.4-fold (0.53 log units) above the measured one, and the stated range covers the measured number.
By their numbers in the MT4 assay, from the lowest: compound 1; then compound 3; then compound 2.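

In the MT4 assay a second replacement at this oxygen on a saturated carbon gives an 11-fold higher number from compound 1 to compound 3 (1.05 log units; beyond the scatter), so the rise is not confined to the four-membered non-aromatic ring of compound 2: it also appears with one six-membered aromatic ring in place of the pair of aromatic rings. The entering group still matters, as the two replacements do not end level, with a 5.6-fold lower number from compound 2 to compound 3 (0.75 log units; beyond the scatter). The same change also lowers the reading in a physicochemical assay for lipophilicity (on this read-out higher numbers stand for higher lipophilicity and lower numbers for lower lipophilicity), where compound 1 gives 2.4 and compound 3 gives 2: the measured distribution coefficient of compound 1, 2.4, and of compound 3, 2, a number 0.40 log units lower (beyond the scatter)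

One pair of compounds cannot show whether lipophilicity follows the tolerated concentration across this series. Also open, on these data alone, is whether the hydrogen-bond donor of the entering group plays any part, which a methyl group on that ring nitrogen or an amine at this oxygen could help to test.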